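The source may report more compounds than this note shows. Statements on the series, on what has been measured and on what is new or still open speak of the compounds shown alone.

Of the compounds shown here, two of a shared core have been measured in a functional assay on A549 cells (Homo sapiens) for cytotoxicity, read by MTT assay, with a stated time of 48 h; a lower number here means a stronger inhibitor, a higher number a weaker inhibitor. Compound 1 `Cc1ccc(Cn2cc(COc3ccc4c(=O)ccoc4c3)nn2)cc1` gives 50700 nM in this assay, while compound 2 `O=c1ccoc2cc(OCc3cn(Cc4cccc([N+](=O)[O-])c4)nn3)ccc12` gives 9450 nM. For the measured compounds named here, the one step between them, a 5.4-fold lower number from compound 1 to compound 2 (0.73 log units; beyond the scatter), leaves compound 2 with the lower of the two numbers. Compound 3 `O=c1ccoc2cc(OCc3cn(Cc4ccc(Br)cc4)nn3)ccc12` is not yet measured; it differs from compound 2 by 4-bromophenyl in place of 3-nitrophenyl on a saturated chain carbon bound to an aromatic nitrogen. Going by the values given here, only that single step bears on this change, and it concerns a different replacement at the same place, so it offers loose guidance: the 3-nitrophenyl that entered there lowered the number, and its removal in favour of 4-bromophenyl is expected to move the number back up, though not necessarily all the way to compound 1. Compound 3 is therefore expected to give 25000 nM in this assay, within a range from 8000 nM to 80000 nM, an expected step of a 2.6-fold higher number from compound 2 to compound 3 (0.42 log units; beyond the scatter).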

Compound 3, half-maximal inhibitory concentration: > 100000 nM
Compound 3: a limit, no number; the forecaster's own chance of this, stated with the estimate: 10%; at least 4.0-fold (0.60 log units) between middle value and limit.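

In this assay compound 3 gives a limit and not a number: the limit of > 100000 nM in this assay, at which 1 of the 3 values shown sits. On a saturated chain carbon bound to an aromatic nitrogen, 4-bromophenyl in place of 3-nitrophenyl brings an at least 10-fold higher number from compound 2 to compound 3 (1.02 log units; beyond the scatter), so among the three compounds only 3-nitrophenyl goes with a lower number, and this replacement does not share that gain. Bromo in place of methyl on an aromatic carbon gives an at least 1.9-fold higher number from compound 1 to compound 3 (0.29 log units; that floor lies within the scatter); since that floor lies within the scatter, these two compounds cannot be put in order.

The compounds shown leave open whether the lower number of compound 2 depends on the nitro group itself. Nor do they show how the phenyl ring at this place would behave if it carried an amine or a carboxylic acid instead.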